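A chloro substituent tried on a chalcone growth inhibitor

This account rests on a few compounds, and the source may have more. Where it says the series, first, only, none or still open, it means among the compounds named here.

Compound 1 `COc1cc(/C=C/C(=O)c2cccc(-n3cc(-c4ccccc4)[nH]c3=O)c2)ccc1O` was tested in a functional assay on TK-10 cells (Homo sapiens) for inhibition (a higher number here means a weaker inhibitor of growth, a lower number a stronger inhibitor of growth), where compound 1 gives 5290 nM. Among the measured compounds shown here, this is the higher of the two numbers known so far; compound 2 `COc1cc(/C=C/C(=O)c2cccc(-n3cc(-c4cc(OC)c(OC)c(OC)c4)[nH]c3=O)c2)cc(OC)c1OC` gives 3000 nM in this assay, a gap within the scatter, so the two cannot be told apart. Compound 3 `COc1cc(/C=C/C(=O)c2cccc(-n3cc(-c4ccc(Cl)cc4)[nH]c3=O)c2)ccc1O` differs from compound 1 by chloro in place of hydrogen on an aromatic carbon. For the measured compounds named here, no measured pair shows this change, so the step in this assay is expected to be small, likely none beyond the scatter, and the estimated step of a 1.3-fold lower number from compound 1 to compound 3 (0.10 log units; within the scatter) reflects that. Compound 3 is therefore expected to give 4200 nM, with a range from 1500 nM to 12000 nM.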

Compound 3, concentration for 50% growth inhibition: 4670 nM
Compound 3: middle estimate off by 1.1-fold (0.05 log units), on the low side, within the range that was stated.
By their numbers in this assay, from the lowest: compounds 2, 3 and 1 (each within the scatter of the next).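

Among the compounds shown here, the change from phenyl to 4-chlorophenyl gives the first comparison in this assay between compounds that differ in one place (a 1.1-fold lower number from compound 1 to compound 3 (0.05 log units; within the scatter)). On this aromatic carbon, para to a large group, chloro in place of hydrogen therefore leaves compound 3 indistinguishable from compound 1. No other measurement available here helps to interpret this result. From the compounds shown here alone, whether an amine or a carboxylic acid at the same position would also stay within the scatter remains open, as does whether chloro would do so elsewhere on the shared core.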